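A few compounds are considered here, and "the series" means these few. Any claim that something is new, unique, unknown or untested is made for them only; others in the source may bear on it.

Compound 1 `Cn1c(-c2ccc([N+](=O)[O-])cc2)nc2cc(C(F)(F)F)ccc21`: >= 100000 nM in an ADME assay on MT4 cells (Homo sapiens) for cytotoxicity, read by MTT assay, with a stated time of 96 h; on this read-out higher numbers stand for lower toxicity in this test and lower numbers for higher toxicity in this test
Compound 2 `CCN(CC)CC(=O)Nc1ccc(-c2nc3cc(C(F)(F)F)ccc3n2C)cc1`: 9000 nM in this assay
Compound 3 `CCC(=O)Nc1ccc(-c2nc3cc(C(F)(F)F)ccc3n2C)cc1`: 8000 nM in this assay

Among the compounds with values here, compound 1 stands at the edge of what the measurements can report: its value of >= 100000 nM is a limit of the assay, not a number, and it is the one compound of the three that sits there (the limit of >= 100000 nM in this assay, at which 1 of the 3 values shown sits). Compounds 2 and 3, which carry an amide in place of the nitro group, show far lower numbers, a step of an at least 11-fold lower number from compound 1 to compound 2 (1.04 log units; beyond the scatter) and one of an at least 12-fold lower number from compound 1 to compound 3 (1.09 log units; beyond the scatter), while the step of a 1.1-fold lower number from compound 2 to compound 3 (0.05 log units; within the scatter) stays within the scatter.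

Compound 4 `O=[N+]([O-])c1ccc(-c2nc3cc(C(F)(F)F)ccc3n2C2CCCCC2)cc1` keeps the nitro group of compound 1 and changes the shared core at another spot: cyclohexyl in place of methyl on an aromatic nitrogen. Within the data shown here, none of the measured steps touches the aromatic nitrogen; all three concern the group on the aromatic carbon or the chain of the amide. Among the measured compounds shown here, the data therefore give no measured step that bears on the cyclohexyl for methyl exchange, and compound 1 itself offers only a limit as a starting point. With that in mind, compound 4 is expected to stay near compound 1, with a step of an at least 1.6-fold lower number from compound 1 to compound 4 (0.22 log units; that floor lies within the scatter) allowed for the uncertainty of the limit, and its value in this assay is estimated at 60000 nM, within a range from 15000 nM to 200000 nM.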

Compound 4, half-maximal cytotoxic concentration: 49000 nM
For compound 4 the middle estimate is 1.2-fold (0.09 log units) above the measured one; the range from low to high includes it.
By their numbers in this assay, from the lowest: compounds 3 and 2 (each within the scatter of the next); then compound 4. At a limit, above all of these: compound 1.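

Within the data shown here, compound 4 gives the first measured number for a compound that keeps the nitro group, and the first look at a change on the aromatic nitrogen, where cyclohexyl replaces methyl. In this assay, this exchange gives an at least 2.0-fold lower number from compound 1 to compound 4 (0.30 log units; that floor lies within the scatter), a floor within the scatter, so the data show neither a real drop nor its full size. Compound 1 stands at a limit and not at a number: the limit of >= 100000 nM in this assay, at which 1 of the 4 values shown sits.

The compounds shown leave open how the read-out changes along a series on this nitrogen, with an ethyl or a phenyl group in place of methyl or cyclohexyl. They also leave open whether cyclohexyl on this nitrogen gives a similar result when the nitro group is replaced by propanoylamino, as in compound 3.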